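The source may hold more compounds than are shown below. What is called first, only, known or untested is meant among the compounds shown, and "the series" means these compounds.

In a functional assay (Oryctolagus cuniculus) for antagonist activity at platelet-activating factor receptor (Cavia porcellus) (on this read-out lower numbers stand for stronger inhibition and higher numbers for weaker inhibition), three compounds have been measured. Compound 1 `O=C(c1ccn2c1CSC2c1cccnc1)c1c[nH]c2cccc(O)c12` gives 327 nM. Compound 2 `CN(C)C(=O)n1cc(C(=O)c2ccn3c2CSC3c2cccnc2)c2ccc(OCc3ccccc3)cc21` gives 17 nM, and compound 3 `CN(C)C(=O)n1cc(C(=O)c2ccn3c2CSC3c2cccnc2)c2ccc(Cc3ccccc3)cc21` gives 13 nM. Among the compounds with values here, the only single-point step among them is a 1.3-fold lower number from compound 2 to compound 3 (0.12 log units; within the scatter), so compound 3 sits within the scatter of compound 2 and far from compound 1.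

Compound 4 `CN(C)C(=O)n1cc(C(=O)c2ccn3c2CSC3c2cccnc2)c2ccc(Oc3ccc(F)cc3)cc21` has not yet been measured. It differs from compound 3 in one place: 4-fluorophenoxy in place of benzyl on an aromatic carbon. Within the data shown here, the one step that bears on this site is a 1.3-fold lower number from compound 2 to compound 3 (0.12 log units; within the scatter), where benzyloxy gave way to benzyl without moving the number beyond the scatter, which suggests that the group at this aromatic carbon can be varied with little effect. Compound 4 brings in a 4-fluorophenoxy group here, and the expectation is a step of about a 1.2-fold higher number from compound 3 to compound 4 (0.09 log units; within the scatter), that is, nothing beyond the scatter. Compound 4 is therefore estimated at 16 nM, with a range of 6 nM to 45 nM.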

Compound 4, inhibition constant: 1.7 nM
Compound 4: the middle estimate sits 9.4-fold (0.97 log units) above what was measured, and the stated range ends above it.
By their numbers in this assay, from the lowest: compound 4; then compounds 3 and 2 (each within the scatter of the next); then compound 1.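

The earlier step at this aromatic carbon, from benzyloxy to benzyl, stayed within the scatter and made the site look indifferent to its group, but 4-fluorophenoxy in place of benzyl gives a 7.6-fold lower number from compound 3 to compound 4 (0.88 log units; beyond the scatter). Likewise, 4-fluorophenyl in place of benzyl on the oxygen gives a 10-fold lower number from compound 2 to compound 4 (1.00 log units; beyond the scatter), so the position does respond to what it carries, and the group with its ring held on the oxygen alone stands apart from the two with a carbon before the ring. Nothing available here accounts for this difference.

Going by these compounds, whether the stronger inhibition goes with the fluorine or with the shorter link stays open, and a plain phenoxy or a 4-fluorobenzyl group at this carbon would separate the two. On these data alone, how the position responds to quite different groups, such as an amine or a carboxylic acid, also remains open.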